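Swapping Methyl for Chloro on the Aryl Ring

This account rests on a few compounds, and the source may have more. Where it says the series, first, only, none or still open, it means among the compounds named here.

Three compounds have been measured in an assay on CHO cells for displacement of a labelled ligand from adenosine receptor A3 (Homo sapiens), read by scintillation counting, with a stated time of 3 h; a higher number here means a weaker inhibitor, a lower number a stronger inhibitor:
Compound 1 `CCCn1c(-c2ccccc2)nc2c(NC3CCOC3)ncnc21` gives 2810 nM.
Compound 2 `Cc1ccc(-c2nc3c(NC4CCCC4)ncnc3n2C)cc1` gives 480 nM.
Compound 3 `Cn1c(-c2ccccc2)nc2c(NC3CCOC3)ncnc21` gives 6260 nM.

Compound 2 stands lowest of the three numbers, and both of its gaps to the other compounds lie beyond the scatter, so it is the strongest inhibitor measured here. Within the data shown here, the only single-place step measured so far is a 2.2-fold higher number from compound 1 to compound 3 (0.35 log units; beyond the scatter), which concerns the chain on the ring nitrogen of the shared core, not the aryl ring.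

Compound 4 `Cn1c(-c2ccc(Cl)cc2)nc2c(NC3CCCC3)ncnc21` differs from compound 2 in one place: chloro in place of methyl on an aromatic carbon. Among the measured compounds shown here, no measured step touches this part of the molecule, so nothing here tells how this assay responds to such a swap. The two groups are alike in size and neither adds a donor or acceptor, so the most cautious expectation is a step of about a 1.1-fold lower number from compound 2 to compound 4 (0.03 log units; within the scatter), that is, no change beyond the scatter, with a wide allowance either way.

Compound 4 is therefore expected to give about 450 nM in this assay, within a range of 150 nM to 1500 nM.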

Compound 4, inhibition constant: 1210 nM
Beside the measured number, compound 4's estimate is 2.7-fold (0.43 log units) below it; the range from low to high includes it.
By their numbers in this assay, from the lowest: compound 2; then compound 4; then compound 1; then compound 3.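

Among these compounds, this step is the first reading of this part of the molecule, since the only earlier step concerned the chain on the ring nitrogen. On this aromatic carbon, para to a large group, going from 4-methylphenyl to 4-chlorophenyl gives a 2.5-fold higher number from compound 2 to compound 4 (0.40 log units; beyond the scatter) in this assay, so methyl gives the lower number of the two. Methyl and chloro match in the computed counts, each with one heavy atom and no hydrogen-bond donors or acceptors, yet the position still responds to the swap beyond the scatter, and nothing available here accounts for the difference.

Going by these compounds, it remains open how a bromo, methoxy or amine group at this same place would compare with methyl and chloro, so two groups do not yet establish a trend for the position. On these data alone, it is also open whether the swap would give a similar step with the amine substituent and ring-nitrogen chain of compound 1, since compound 1 and compound 4 differ in more than one place and their numbers cannot be read as a single change.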